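Ethyl in place of chloro on the benzoxazole-free core

The source may hold more compounds than are shown below. What is called first, only, known or untested is meant among the compounds shown, and "the series" means these compounds.

Three compounds of this series carry a methylpiperazine on a shared core and have been tested in a functional assay on ileum (strain Hartley) for agonist activity at 5-hydroxytryptamine receptor 3A (Cavia porcellus); a lower number here means a less potent compound, a higher number a more potent compound, by a factor of ten per unit of this negative logarithm. Compound 1 `Cc1cc(Cl)c2oc(N3CCN(C)CC3)nc2c1` gives 6.22 in this assay. Among the compounds with values here, compound 3 `CN1CCN(c2nc3cc(Cl)cc(Cl)c3o2)CC1` gives 6.51, and the only measured single-point step, a number 0.29 log units higher from compound 1 to compound 3 (within the scatter), stays within the scatter. As far as these compounds go, compound 2 `CCc1ccc2oc(N3CCN(C)CC3)nc2c1` returns only a limit of the assay, < 4, so the number itself is unknown (the limit of < 4 in this assay, at which 1 of the 3 values shown sits). Among the two numbers present, compound 1 sits with compound 3 inside the scatter; the remaining value is a limit.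

Compound 4 `CCc1cc(C)cc2nc(N3CCN(C)CC3)oc12` differs from compound 1 in one place: ethyl in place of chloro on an aromatic carbon. Within the data shown here, no measured step covers this exact exchange. Among the measured compounds shown here, the one step known, from compound 1 to compound 3, swaps a methyl for a chloro at another carbon and is within the scatter, so it says little about removing the chloro. Compound 2, which carries an ethyl and lacks the chloro, gives only a limit, which points to a loss when the chloro goes, though its ethyl sits at a different carbon.

A downward step, a number 1.22 log units lower from compound 1 to compound 4 (beyond the scatter), is therefore expected for compound 4, with the estimate 5 spanning from 4 to 6.2 in this assay.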

Compound 4, negative logarithm of the half-maximal effective concentration: 6.46
Compound 4: the middle estimate sits 1.46 log units below what was measured, and the stated range ends below it.
By their numbers in this assay, from the lowest: compounds 1, 4 and 3 (each within the scatter of the next). At a limit, below all of these: compound 2.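

Notes on the chloro position: in this assay, ethyl in place of chloro on this aromatic carbon, ortho to a fused ring and meta to a methyl group, gives a number 0.24 log units higher from compound 1 to compound 4 (within the scatter). Compound 4 gives 6.46 without any chloro on the core, so in this pair the chloro is not required at this carbon, and ethyl, with its 2 heavy atoms, is accepted there in place of the 1 heavy atom of chloro. Compound 2 remains a limit of the assay and differs from compound 4 in more than one place, so it gives no comparison for this position: the limit of < 4 in this assay, at which 1 of the 4 values shown sits.

Only chloro and ethyl are shown on this carbon with the methyl group in place, so whether a longer chain such as propyl, an amine or a carboxylic acid would be accepted there remains open. Within the data shown here, also open is whether the ethyl of compound 4 keeps its level in this assay when the methyl group is exchanged, since no single-place step at that carbon starts from compound 4.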